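Replacing the ester of compound 2 with a cyclic imide

This account rests on a few compounds, and the source may have more. Where it says the series, first, only, none or still open, it means among the compounds named here.

Measured compounds:
compound 1, `C=CC(=O)Nc1cc(C(F)(F)F)cc(C(F)(F)F)c1`, 0.8 h
compound 2, `C=CC(=O)Oc1cc(C(F)(F)F)cc(C(F)(F)F)c1`, < 0.017 h

Both compounds share a core carrying two trifluoromethyl groups and differ only in the group attached to the remaining aromatic carbon. In an ADME assay for pharmacokinetics, read by LC-MS, in phosphate buffer, with a stated time of 72 h, at pH 7.4, tested at 250 uM (a higher number here means that the compound lasts longer, a lower number that the compound disappears faster), compound 1 gives 0.8 h. For compound 2 only a limit is known in this assay, < 0.017 h, so its half-life is not a number but a bound. Among the measured compounds shown here, the one measured step, an at least 47-fold lower number from compound 1 to compound 2 (1.67 log units; beyond the scatter), is large and runs toward a shorter half-life, and the value it ends at is the limit of < 0.017 h in this assay, at which 1 of the 2 values shown sits.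

Compound 3, `O=C1C=CC(=O)N1c1cc(C(F)(F)F)cc(C(F)(F)F)c1`, is reached from compound 2 by the change (a group of 7 heavy atoms (4 carbon, 1 nitrogen, 2 oxygen; one five-membered non-aromatic ring with 1 hetero atom) in place of a group of 5 heavy atoms (3 carbon, 2 oxygen; no ring), on an aromatic carbon). For the measured compounds named here, no measured step covers an exchange of this kind, so the step from compound 1 to compound 2 offers only a loose guide: it shows that swapping the group on this carbon can move the half-life a great deal. For compound 3 the expected half-life is 0.3 h, with a range from 0.02 h to 5 h, which means an expected step of an at least 17-fold higher number from compound 2 to compound 3 (1.24 log units; beyond the scatter).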

Compound 3, half-life: < 0.017 h
Compound 3: a limit, no number; the forecaster's own chance of this, stated with the estimate: 30%; middle value at least 17-fold (1.24 log units) away from the limit.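

In this assay compound 3 gives < 0.017 h, which is a limit and not a number. Of the three groups shown on this aromatic carbon, only the (vinylcarbonyl)amino group gives a measured half-life, and closing the group into the five-membered imide ring brings an at least 47-fold lower number from compound 1 to compound 3 (1.67 log units; beyond the scatter). The step between the ester and the imide cannot be read, because both compounds end at the same limit of the assay: the limit of < 0.017 h in this assay, at which 2 of the 3 values shown sit.

From the compounds shown here alone, whether the short half-life of compound 3 goes with the ring itself, its two carbonyl groups or the double bond inside the ring stays open, and a saturated five-membered imide or an open-chain propanoylamino group, with no carbon-carbon double bond, would help to separate these features. Going by these compounds, how far the true half-lives of compound 2 and compound 3 lie beyond their shared limit, and whether they differ at all, also stays open.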